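This account rests on a few compounds, and the source may have more. Where it says the series, first, only, none or still open, it means among the compounds named here.

Values in an ADME assay on HepG2 cells (Homo sapiens) for cytotoxicity, read by MTT assay, with a stated time of 72 h; a higher number here means that more compound is tolerated, a lower number that less compound is tolerated:
Compound 1 `COc1ccccc1C#Cc1cc(Cl)cn2c([N+](=O)[O-])c(CS(=O)(=O)c3ccccc3)nc12`: > 3900 nM, a limit.
Compound 2 `O=[N+]([O-])c1c(CS(=O)(=O)c2ccccc2)nc2c(C#Cc3ccccc3F)cc(Cl)cn12`: > 3900 nM, a limit.
Compound 3 `O=[N+]([O-])c1c(CS(=O)(=O)c2ccccc2)nc2c(C#CCOc3ccccc3)cc(Cl)cn12`: 8400 nM.

Compound 3 alone gives an actual number. The remainder is the limit of > 3900 nM in this assay, at which 2 of the 3 values shown sit. The next compound is compound 4 `CC(O)(C#Cc1cc(Cl)cn2c([N+](=O)[O-])c(CS(=O)(=O)c3ccccc3)nc12)c1ccccc1`, and the change is 1-hydroxy-1-phenylethyl in place of phenoxymethyl on a triple-bonded carbon. For the measured compounds named here, two measured steps touch this same place, a step that the limit leaves unreadable from compound 1 to compound 3 and a step that the limit leaves unreadable from compound 2 to compound 3, and neither has a readable size. Going by the values given here, with compound 3 at 8400 nM and no step to scale from, no shift beyond the scatter is expected in this assay, in either direction. The expected step is a 1.1-fold lower number from compound 3 to compound 4 (0.02 log units; within the scatter). The estimate for compound 4 is 8000 nM, with an expected range from 3500 nM to 18000 nM.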

Compound 4, half-maximal cytotoxic concentration: 18800 nM
For compound 4 the middle estimate is 2.4-fold (0.37 log units) below the measured one; the measured number lies above the stated range.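

In this assay, 1-hydroxy-1-phenylethyl in place of phenoxymethyl on a triple-bonded carbon gives a 2.2-fold higher number from compound 3 to compound 4 (0.35 log units; beyond the scatter). For the compounds shown here, this is the first step of readable size at this place, and it shows that the group on the triple-bonded carbon can move this read-out beyond the scatter. The steps to compound 4 from compound 1 and compound 2 cannot be read, as both of those compounds stand at a limit: the limit of > 3900 nM in this assay, at which 2 of the 4 values shown sit.

As far as these compounds go, it remains open whether the hydroxy of 1-hydroxy-1-phenylethyl accounts for the step. From the compounds shown here alone, how an amine or a carboxylic acid on this carbon would read in this assay also stays open.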